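The source may report more compounds than this note shows. Statements on the series, on what has been measured and on what is new or still open speak of the compounds shown alone.

Compound 1, with the structure `COc1ccc(-c2c(Cl)c(=O)c3c(OC)cc(OC)cc3n2S(=O)(=O)c2ccc(OC)cc2)cc1`, and compound 2, with the structure `COc1ccc(-c2cc(=O)c3c(OC)cc(OC)cc3n2S(=O)(=O)c2ccc(C=O)cc2)cc1`, share one core and were both examined in an ADME assay on BJ cells (Homo sapiens) for antiproliferative activity, with a stated time of 72 h; on this read-out higher numbers stand for an effect only at larger amounts of compound and lower numbers for an effect already at smaller amounts. In this assay compound 1 gives 90000 nM. For compound 2 this assay returns only a limit, > 34400 nM, so the number itself is not known. Among the compounds with values here, the two compounds differ in more than one place, so no single step can be drawn between them; all that the pair shows is one value high on the scale and one result that is a limit. Among the two results shown, (the limit of > 34400 nM in this assay, at which 1 of the 2 values shown sits).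

Compound 3, with the structure `COc1ccc(-c2cc(=O)c3c(OC)cc(OC)cc3n2S(=O)(=O)c2ccc(Br)cc2)cc1`, has not yet been measured in this assay. It differs from compound 2 by bromo in place of formyl on an aromatic carbon. Within the data shown here, no measured step shows what such a change does here. On the evidence of compound 2 sitting at a limit, > 34400 nM, compound 3 is expected to stay near that region, with a step that the limit leaves unreadable from compound 2 to compound 3 that is not expected to go beyond the scatter. The estimated value for compound 3 in this assay is 40000 nM, within a range from 15000 nM to 120000 nM.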

Compound 3, half-maximal effective concentration: > 86200 nM
Compound 3 gave a limit, no number (the forecaster's own chance of this, stated with the estimate: 50%); at least 2.1-fold (0.33 log units) between middle value and limit.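

In this assay compound 3 returns only a limit, > 86200 nM. Compound 2 also returns only a limit, > 34400 nM. With a limit on each side, no step can be read between compound 2 and compound 3. The compounds shown leave open whether bromo in place of formyl on an aromatic carbon changes the result in this assay at all.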